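Swapping Nitro for Amino in Two Related Pairs

The source may report more compounds than this note shows. Statements on the series, on what has been measured and on what is new or still open speak of the compounds shown alone.

Among the measured compounds shown here, two pairs of compounds share a single structural change, and only one pair has been measured so far. Compound 1 `COc1ccc(/C=C/c2ccc3ccccc3c2)cc1[N+](=O)[O-]` carries a nitro group on an aromatic carbon, while compound 2 `COc1ccc(/C=C/c2ccc3ccccc3c2)cc1N` carries an amino group at that position. In a functional assay on HT-29 cells (Homo sapiens) for inhibition (on this read-out lower numbers stand for stronger inhibition and higher numbers for weaker inhibition), compound 1 gives > 5000 nM, which is a limit of the assay rather than a number. In this assay compound 2 gives > 5000 nM, again a limit. The change between them is amino in place of nitro on an aromatic carbon, and the resulting step is a step that the two limits leave unreadable from compound 1 to compound 2.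

Compound 3 `COc1cc(/C=C/c2ccc(N(C)C)c([N+](=O)[O-])c2)cc(OC)c1OC` is built on a different core; the difference between the two cores is not broken down here. In this assay compound 3 gives > 5000 nM, which is a limit. Compound 4 `COc1cc(/C=C/c2ccc(N(C)C)c(N)c2)cc(OC)c1OC` has not yet been measured and differs from compound 3 by amino in place of nitro on an aromatic carbon. The surroundings are not identical: in the first pair the site is ortho to a methoxy group, in the second it is ortho to a dimethylamino group, so this is the same kind of change rather than the same change.

For the measured compounds named here, because the limit of > 5000 nM in this assay, at which 3 of the 3 values shown sit, sets the only evidence available, the earlier pair offers no readable direction. On that basis the expected step is a step that the limit leaves unreadable from compound 3 to compound 4. Compound 4 is estimated at 8000 nM, with a likely span from 3000 nM to 30000 nM, and most probably it too will be reported only as a limit.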

Compound 4, half-maximal inhibitory concentration: 300 nM
Compound 4: the middle estimate sits 27-fold (1.43 log units) above what was measured; the measured number lies below the stated range.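

In this assay, placing amino instead of nitro on the core of compound 3, ortho to a dimethylamino group, gives an at least 16-fold lower number from compound 3 to compound 4 (1.22 log units; beyond the scatter). This shows that the change can matter greatly on this core, but whether it carries over from the other core cannot be said, because the step between compound 1 and compound 2 cannot be read and the new step gives only a minimum size: the limit of > 5000 nM in this assay, at which 3 of the 4 values shown sit. The two sites also have different surroundings, so even a readable step on the first core would compare the same kind of change rather than the identical change, and a single result on one core sets no rule for the series.

From the compounds shown here alone, it remains open which features of the core of compound 4 go with the lower number, and a methoxy group in place of its dimethylamino group would test one of them. Going by these compounds, it also remains open how a methylamino, acetamido or hydroxyl group in place of the amino group would read in this assay, which would show how specific the result is to the amino group.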